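A few compounds are considered here, and "the series" means these few. Any claim that something is new, unique, unknown or untested is made for them only; others in the source may bear on it.

Measured compounds:
- compound 1 `COC(=O)C(O)Cn1cnc2c(N)ncnc21`: > 400 ug/mL
- compound 2 `CC(C)(C)OC(=O)C(O)Cn1cnc2c(N)ncnc21`: > 400 ug/mL

In a functional assay on HeLa cells (Homo sapiens) for cytotoxicity (on this read-out lower numbers stand for higher toxicity in this test and higher numbers for lower toxicity in this test), compound 1 gives > 400 ug/mL, which is a limit of the assay and not a number. Compound 2 gives > 400 ug/mL, likewise a limit. On these data alone, the step that the two limits leave unreadable from compound 1 to compound 2 therefore cannot be read, and its size stays unknown. Going by the values given here, the whole series sits at the limit of > 400 ug/mL in this assay, at which 2 of the 2 values shown sit, so no measured step gives a usable size.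

Compound 3 `CCC(C)OC(=O)C(O)Cn1cnc2c(N)ncnc21` is not yet measured. It differs from compound 1 by sec-butyl in place of methyl on an oxygen next to a carbonyl group. Among the compounds with values here, the only measured step of a comparable kind, from methyl to tert-butyl on the same oxygen, is unreadable, so no direction or size can be derived from it.

Compound 3 is expected to give about 400 ug/mL, within a range of 200 ug/mL to 800 ug/mL, most likely again reported as a limit. The expected step of a number no higher from compound 1 to compound 3 (the limit leaves the size open) is estimated as no change beyond the scatter.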

Compound 3, minimum cytotoxic concentration: > 400 ug/mL
Compound 3: a limit, no number; the forecaster's own chance of this, stated with the estimate: 85%; the middle value sits exactly at the limit.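

In this assay compound 3 gives > 400 ug/mL, a limit of the assay and not a number. Going by these compounds alone, no step among compound 1, compound 2 and compound 3 can be read, as all three values sit at one limit: the limit of > 400 ug/mL in this assay, at which 3 of the 3 values shown sit. The compounds shown leave open whether methyl, tert-butyl and sec-butyl on this oxygen differ at all in this assay.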